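Swapping a methyl for cyclohexyl in a cytotoxicity test

The compounds below may be only part of what the source reports. "The series", "measured", "known", "first", "only" and "open" are said of these compounds alone.

Compound 1 `CN(C)c1nc(Cc2c(F)cccc2F)cc(=O)[nH]1`: > 94000 nM
Compound 2 `CC1CCCCN1c1nc(Cc2c(F)cccc2F)cc(=O)[nH]1`: > 78000 nM
Compound 3 `Cc1c(Cc2c(F)cccc2F)nc(N(C)C)[nH]c1=O`: > 89000 nM

In an ADME assay on MT4 cells (Homo sapiens) for cytotoxicity, read by MTT assay, with a stated time of 4 days (on this read-out lower numbers stand for higher toxicity in this test and higher numbers for lower toxicity in this test), compound 3 gives only a limit, > 89000 nM. Compound 1 and compound 2 also give only limits, so the three cannot be ranked.

Compound 4 `Cc1c(Cc2c(F)cccc2F)nc(N(C)C2CCCCC2)[nH]c1=O` has not yet been measured. It differs from compound 3 by a single change: cyclohexyl in place of methyl on a nitrogen on an aromatic ring. Here cyclohexyl takes the place of methyl on a nitrogen on an aromatic ring, so dimethylamino becomes cyclohexyl(methyl)amino.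

Among the compounds with values here, two measured steps bear on this. The closer one is a step that the two limits leave unreadable from compound 1 to compound 2, as it too replaces dimethylamino. The other is a step that the two limits leave unreadable from compound 1 to compound 3, which brings in the methyl on an aromatic carbon that compound 4 keeps. Neither step has a readable size, so neither offers a size or a direction to carry over. Only a slight move toward higher toxicity is expected, and it is held loosely. The expected change is an at least 1.4-fold lower number from compound 3 to compound 4 (0.17 log units; that floor lies within the scatter). Compound 4 is estimated at 60000 nM, with an expected range from 18000 nM to 100000 nM.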

Compound 4, half-maximal cytotoxic concentration: > 72000 nM
Compound 4: no number, only a limit; the forecaster's own chance of this, stated with the estimate: 60%; at least 1.2-fold (0.07 log units) between middle value and limit.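

In this assay compound 4 gives > 72000 nM, which is a limit and not a number. Compound 3 also gives only a limit, so the step between compound 3 and compound 4 cannot be read in size or direction. The compounds shown leave open at what concentration any of the four harms these cells, and whether cyclohexyl in place of methyl changes that concentration at all.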